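The source may hold more compounds than are shown below. What is called first, only, known or untested is meant among the compounds shown, and "the series" means these compounds.

Compound 2, `Cc1c(C#Cc2ccc(CCC(=O)O)cc2)ccnc1Cl`, is the anchor of this comparison. In an in vitro functional assay on 1321-N1 cells for agonist activity at Free fatty acid receptor 1 (Homo sapiens), read by fluorescence, spectrophotometry and calcium flux (a higher number here means that more compound is needed for the effect, a lower number that less compound is needed), compound 2 gives 135 nM, the second highest of the three numbers. Compound 3, `Cc1c(C#Cc2ccc(CCC(=O)O)cc2)cc(Cl)nc1Cl`, gives 43.7 nM in this assay, and the step of a 3.1-fold lower number from compound 2 to compound 3 (0.49 log units; beyond the scatter) is modest but lies beyond the scatter. Compound 1, `Cc1ccccc1-c1cc(C#Cc2ccc(CCC(=O)O)cc2)ccn1`, gives 1070 nM in this assay; the two values of compound 1 and compound 2 show compound 1 far higher. Compound 4, `O=C(O)CCc1ccc(C#Cc2ccnc(Cl)c2Cc2ccccc2)cc1`, differs from compound 2 by phenyl in place of hydrogen on a saturated chain carbon bound to an aromatic carbon, or, cut one bond further out, methyl to benzyl. For the measured compounds named here, no measured step adds a phenyl in this place, so the only guide is the size of the chloro step. Compound 4 is therefore expected to show a small step, a 1.2-fold lower number from compound 2 to compound 4 (0.09 log units; within the scatter), toward a lower number. The estimate for compound 4 in this assay is 110 nM, within 35 nM to 350 nM.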

Compound 4, half-maximal effective concentration: 794 nM
Beside the measured number, compound 4's estimate is 7.2-fold (0.86 log units) below it; the whole stated range lies below it.
By their numbers in this assay, from the lowest: compound 3; then compound 2; then compounds 4 and 1 (each within the scatter of the next).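

Phenyl in place of hydrogen on a saturated chain carbon bound to an aromatic carbon, or methyl to benzyl, gives a 5.9-fold higher number from compound 2 to compound 4 (0.77 log units; beyond the scatter). This is the only step shown at this place, and it runs opposite in direction to the chloro step, a 3.1-fold lower number from compound 2 to compound 3 (0.49 log units; beyond the scatter), so that step says little about this change. Nothing available explains the rise in the number. The compounds shown leave open whether an ethyl group at this place would give a number closer to that of compound 2 or compound 4. They also leave open whether a second chloro would lower the number on the benzyl compound.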